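A few compounds are considered here, and "the series" means these few. Any claim that something is new, unique, unknown or untested is made for them only; others in the source may bear on it.

Going by the values given here, in a functional assay with Mus musculus as the target (on this read-out lower numbers stand for an effect already at smaller amounts and higher numbers for an effect only at larger amounts of compound), three compounds have numbers so far. Compound 1 `COc1ccc(Cn2c(=O)n(C3OC(CO)[C@@H](O)[C@H]3O)c3nc(N)nc(O)c32)cc1` gives 2 uM, compound 3 `C=CCn1c(=O)n(CCCC)c2nc(N)nc(O)c21` gives 11 uM, and compound 2 `CN(C)CCCn1c(=O)n(C2OC(CO)[C@@H](O)[C@H]2O)c2nc(N)nc(O)c21` gives 820 uM, the highest of the three. Compound 4 `CCCCCCn1c(=O)n(C2OC(CO)[C@@H](O)[C@H]2O)c2nc(N)nc(O)c21` has not yet been measured. It differs from compound 2 as follows: propyl in place of dimethylamino on a saturated chain carbon, three bonds along the chain from an aromatic nitrogen. This places propyl where dimethylamino stood, on a saturated chain carbon, three bonds along the chain from an aromatic nitrogen. Among the compounds with values here, the one measured step that bears on this change is a 410-fold higher number from compound 1 to compound 2 (2.61 log units; beyond the scatter). That step is large, and it put 2-(dimethylamino)ethyl in place of 4-methoxyphenyl. Taking out the dimethylamino is therefore expected to reverse part of that step, giving a large move to a lower number in this assay. Within the data shown here, a full return is not expected, as propyl is not 4-methoxyphenyl and no measured compound carries the hexyl chain. The estimated change is a 55-fold lower number from compound 2 to compound 4 (1.74 log units; beyond the scatter). For compound 4 the expected value is 15 uM, within an estimated range of 3 uM to 80 uM.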

Compound 4, concentration for half-maximal effect: 600 uM
Compound 4: the middle estimate sits 40-fold (1.60 log units) below what was measured; measured number above the stated range.
By their numbers in this assay, from the lowest: compound 1; then compound 3; then compounds 4 and 2 (each within the scatter of the next).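

In this assay, putting propyl in place of dimethylamino, on a saturated chain carbon three bonds along the chain from an aromatic nitrogen, gives a 1.4-fold lower number from compound 2 to compound 4 (0.14 log units; within the scatter), so at this position the amine and the plain alkyl end cannot be told apart. The gap to compound 1 remains with the amine gone: pentyl in place of 4-methoxyphenyl, on a saturated chain carbon bound to an aromatic nitrogen, gives a 300-fold higher number from compound 1 to compound 4 (2.48 log units; beyond the scatter), and the large step therefore does not depend on the dimethylamino group. No supporting information is available to explain either result.

The compounds shown leave open whether the 4-methoxyphenyl ring as a whole or its methoxy group carries the difference, which an unsubstituted phenyl at this place would address. They also leave open whether a carboxylic acid at the chain end or a shorter chain would behave like propyl and dimethylamino.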